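Dropping One Methoxy from the Aryl Amine with the Highest Number

The compounds below may be only part of what the source reports. "The series", "measured", "known", "first", "only" and "open" are said of these compounds alone.

The three measured compounds share one core carrying an aryl amine. Compound 1 (`Cc1sc2c(Nc3ccc(C#N)cc3)cccc2c1C`) bears a nitrile on its aryl ring and gives 67.3% in a functional assay for inhibition, with a stated time of 2 h, tested at 0.0312 g/L; on this read-out lower numbers stand for less inhibition and higher numbers for more inhibition at the one concentration tested (going by the name of the read-out). Compound 2 (`Cc1sc2c(Nc3cccnc3)cccc2c1C`) carries a pyridyl ring in place of that aryl ring and gives 65.4% in the same assay. Compound 3 (`COc1ccc(Nc2cccc3c(C)c(C)sc23)cc1OC`) has two methoxy groups on its aryl ring and gives 91.4%, the highest of the three numbers; compound 1 sits nearest to it, lower by a margin beyond the scatter, and compound 2 furthest, also lower by a margin beyond the scatter.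

Compound 4 (`COc1ccc(Nc2cccc3c(C)c(C)sc23)cc1`) has not been measured. It differs from compound 3 in one place: hydrogen in place of methoxy on an aromatic carbon.

Among the measured compounds shown here, no step between measured compounds isolates a single methoxy, so the expectation for this change rests on the three values alone. Because compound 3 gives 91.4% while compound 1 gives 67.3% with a different aryl substitution, compound 4 is estimated to move downward but to stay above the single-substituent compounds. The step from compound 3 to compound 4 is estimated at a number 11.4 percentage points lower from compound 3 to compound 4 (beyond the scatter), a drop that may or may not exceed the scatter. Compound 4 is estimated to give 80%, within a range from 62% to 94%.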

Compound 4, a percentage reported as inhibition, at one concentration (the size of the read-out at that concentration, not a potency): 96.8%
Compound 4: middle estimate off by 16.8 percentage points, on the low side; the whole stated range lies below it.
By their numbers in this assay, from the lowest: compounds 2 and 1 (each within the scatter of the next); then compounds 3 and 4 (each within the scatter of the next).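

In this assay, hydrogen in place of methoxy on an aromatic carbon, ortho to a methoxy group, gives a number 5.4 percentage points higher from compound 3 to compound 4 (within the scatter), so this read-out does not separate hydrogen from methoxy at this position. Among the compounds shown here, a high number therefore does not depend on the second methoxy group: the one methoxy group left in compound 4 is enough for a number that stands level with that of compound 3, within the scatter. The other step gives the first comparison in one place for the remaining methoxy group, with methoxy in place of cyano on an aromatic carbon giving a number 29.5 percentage points higher from compound 1 to compound 4 (beyond the scatter), a change well beyond the scatter; no measurement shown here bears on why either step has the size it has.

The compounds shown leave open whether the number holds with hydrogen in place of the remaining methoxy group, or with a hydroxyl, an ethoxy or an amine there. With one concentration tested, they also leave open whether compound 3 and compound 4 would still stand level at lower concentrations.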